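The source may report more compounds than this note shows. Statements on the series, on what has been measured and on what is new or still open speak of the compounds shown alone.

Measured so far:
Compound 1, `COc1cc2cc(Oc3ccc(NC(=O)Nc4cccc(C(F)(F)F)c4)cc3)c(C)nc2cc1OC`: 10800 nM in a functional assay on UO-31 cells (Homo sapiens) for inhibition, read by sulforhodamine B assay, with a stated time of 48 h; a lower number here means a stronger inhibitor of growth, a higher number a weaker inhibitor of growth.
Compound 2, `COc1cc2cc(Oc3ccc(NC(=O)Nc4ccc(Cl)c(C(F)(F)F)c4)cc3)c(C)nc2cc1OC`: 2380 nM.

Among the compounds with values here, compound 2 holds the lower of the two numbers; its only neighbour is compound 1, separated by the step of a 4.5-fold lower number from compound 1 to compound 2 (0.66 log units; beyond the scatter). Compound 3, `COc1cc2cc(Oc3ccc(NC(=O)Nc4ccc(Cl)c(Cl)c4)cc3)c(C)nc2cc1OC`, differs from compound 2 by chloro in place of trifluoromethyl on an aromatic carbon. Within the data shown here, no measured step swaps these two groups, and the one known step altered a different position, so it gives no direct guide. Without such a guide, the expected step is a 1.5-fold higher number from compound 2 to compound 3 (0.17 log units; within the scatter) in this assay, modest at most in either direction. Compound 3 is estimated at 3500 nM, ranging from 1200 nM to 10000 nM.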

Compound 3, concentration for total growth inhibition: 12600 nM
Compound 3: the middle estimate sits 3.6-fold (0.56 log units) below what was measured, and the stated range ends below it.
By their numbers in this assay, from the lowest: compound 2; then compounds 1 and 3 (each within the scatter of the next).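

In this assay, within the data shown here, this is the first change at the position holding trifluoromethyl, and the position proves sensitive: chloro there gives a 5.3-fold higher number from compound 2 to compound 3 (0.72 log units; beyond the scatter). The two groups are therefore not interchangeable in this series. The step of a 1.2-fold higher number from compound 1 to compound 3 (0.07 log units; within the scatter) stays within the scatter, so the benefit of the added chloro in compound 2 appears here only with trifluoromethyl kept in place.

No available data give a reason for this difference. From the compounds shown here alone, whether a methyl group or a nitrile at this position would behave more like trifluoromethyl or like chloro remains open.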